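Swapping a chloro for a methyl on the amide-bound ring

This account rests on a few compounds, and the source may have more. Where it says the series, first, only, none or still open, it means among the compounds named here.

Of the compounds shown here, three built on one shared core have been tested in a functional assay on P388 cells (Mus musculus) for inhibition, read by MTT assay, with a stated time of 72 h; a lower number here means a stronger inhibitor, a higher number a weaker inhibitor. Compound 1 `COc1ccccc1NC(=O)c1ccc(/N=N\c2c[nH]c3ccccc23)cc1` was reported as "not active" (no number reported) in this assay. Compound 2 `O=C(Nc1ccc([N+](=O)[O-])cc1)c1ccc(/N=N\c2c[nH]c3ccccc23)cc1` gives 11200 nM in this assay. For the measured compounds named here, compound 3 `O=C(Nc1ccc(Cl)cc1)c1ccc(/N=N\c2c[nH]c3ccccc23)cc1` gives 80000 nM in this assay, the highest of the two numbers recorded; the single measured step, a 7.1-fold higher number from compound 2 to compound 3 (0.85 log units; beyond the scatter), separates it from compound 2, so compound 3 is the weaker inhibitor of that pair, while the third compound yielded no number at all.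

Compound 4 `Cc1cccc(NC(=O)c2ccc(/N=N\c3c[nH]c4ccccc34)cc2)c1` has not yet been measured. It differs from compound 3 in one place: 3-methylphenyl in place of 4-chlorophenyl on an amide-type nitrogen. Going by the values given here, the only measured step, a 7.1-fold higher number from compound 2 to compound 3 (0.85 log units; beyond the scatter), also concerns the group on the amide-type nitrogen, but it exchanges nitro for chloro rather than chloro for methyl, so it bears only loosely on the present change. Among the compounds with values here, no measured compound carries a methyl group, and the one compound with a group other than nitro or chloro on this ring, compound 1, gave no number. The step is therefore expected to be small or to run toward a weaker inhibitor, a 1.3-fold higher number from compound 3 to compound 4 (0.10 log units; within the scatter). For compound 4 the estimate in this assay is 100000 nM, with a range from 30000 nM to 300000 nM, and a fair chance that only a limit is reported.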

Compound 4, half-maximal inhibitory concentration: 300 nM
The estimate for compound 4 lay 330-fold (2.52 log units) above the measured number, and the stated range ends above it.
By their numbers in this assay, from the lowest: compound 4; then compound 2; then compound 3.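

In this assay, for the compounds shown here, the group on the amide-type nitrogen can move the number much further than the earlier compounds showed: the nitro-to-chloro step was modest, whereas a 270-fold lower number from compound 3 to compound 4 (2.43 log units; beyond the scatter) is large. This is not just a gain over the weaker member of the earlier pair, since a 37-fold lower number from compound 2 to compound 4 (1.57 log units; beyond the scatter) is also large, which places 3-methylphenyl well ahead of both the 4-chlorophenyl and 4-nitrophenyl groups at this position. Nothing available here explains why the swap has so strong an effect on the result.

Going by their names, 3-methylphenyl differs from 4-chlorophenyl both in the group carried on the ring and in where that group sits, and the compounds shown cannot separate these two changes, so it remains unclear whether the methyl group itself or its placement accounts for the drop. From the compounds shown here alone, it also remains open whether the low number is particular to methyl or would hold for a longer chain such as ethyl, or for an amine or a carboxylic acid on the same ring.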